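Swapping the chain on the ring nitrogen for a benzyl group

The source may report more compounds than this note shows. Statements on the series, on what has been measured and on what is new or still open speak of the compounds shown alone.

Measured compounds:
compound 1 `CCC(C)(C)Cn1nc(-c2cccs2)c(O)c(C2=NS(=O)(=O)c3cc(OCC(N)=O)ccc3N2)c1=O`: > 1 h
compound 2 `CCC(C)CCn1nc(-c2cccs2)c(O)c(C2=NS(=O)(=O)c3cc(OCC(N)=O)ccc3N2)c1=O`: 0.417 h

Of the compounds shown here, two have been tested in an in vitro ADME assay on microsomes from liver (Homo sapiens) for metabolic stability; on this read-out higher numbers stand for a longer-lived compound and lower numbers for a shorter-lived compound. Compound 1 gives only a limit of the assay, > 1 h. Among the compounds with values here, compound 2 gives 0.417 h, the only number among the two, and the step of an at least 2.3-fold lower number from compound 1 to compound 2 (0.37 log units; beyond the scatter) is beyond the scatter. The unmeasured compound 3 `NC(=O)COc1ccc2c(c1)S(=O)(=O)N=C(c1c(O)c(-c3cccs3)nn(Cc3ccccc3)c1=O)N2` differs from compound 2 in one place: phenyl in place of 2-methylbutyl on a saturated chain carbon bound to an aromatic nitrogen. The one measured step changed the same position, yet it swapped one saturated chain for another, so it does not show how a phenyl group behaves there; no shown step bears directly on the new change. With so little to lean on, the expected step of a 1.2-fold higher number from compound 2 to compound 3 (0.08 log units; within the scatter) is not beyond the scatter. Compound 3 is therefore estimated at 0.5 h, with a range from 0.2 h to 1.5 h.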

Compound 3, half-life: 0.383 h
Estimate against measurement, compound 3: 1.3-fold (0.12 log units) above; low and high end bracket the measured number.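

In this assay, replacing the saturated 3-methylpentyl chain with benzyl gives a 1.1-fold lower number from compound 2 to compound 3 (0.04 log units; within the scatter), so on this read-out the two groups cannot be told apart at this place. Replacing 1,1-dimethylpropyl with phenyl on the same saturated chain carbon gives an at least 2.6-fold lower number from compound 1 to compound 3 (0.41 log units; beyond the scatter), so the ring-bearing compound also falls short of compound 1, just as the open-chain compound 2 does. Compound 1 stands at a limit of the assay and not at a number: the limit of > 1 h in this assay, at which 1 of the 3 values shown sits.

From the compounds shown here alone, the true size of the gap to compound 1 stays open, as only its lower bound can be read. Also open, going by these compounds, is what a fluorine or a methoxy group on the benzyl ring, or a chain ending in an amine, would do at this place.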